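This account rests on a few compounds, and the source may have more. Where it says the series, first, only, none or still open, it means among the compounds named here.

Compounds measured in an assay on cells for inhibition of HSP60/HSP10 (Homo sapiens), with a stated time of 60 min; a lower number here means a stronger inhibitor, a higher number a weaker inhibitor:
- compound 1, `O=S(=O)(Nc1ccc(-c2nc3ccccc3o2)cc1)c1ccc(Cl)c(C(F)(F)F)c1`, gives 12000 nM
- compound 2, `O=S(=O)(Nc1ccc(-c2nc3ccccc3o2)cc1)c1ccc(F)c(C(F)(F)F)c1`, gives 28000 nM
- compound 3, `O=S(=O)(Nc1ccc2oc(-c3ccccc3)nc2c1)c1ccc(O)cc1`, gives 88000 nM

Compound 1 holds the lowest number of the three in this assay. Its nearest neighbour is compound 2, reached by fluoro in place of chloro on an aromatic carbon, a step of a 2.3-fold higher number from compound 1 to compound 2 (0.37 log units; beyond the scatter). Within the data shown here, compound 3, which differs from compound 1 in several places at once, stands furthest away, and no single step connects the two; their values alone show the gap.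

The unmeasured compound is compound 4, `O=S(=O)(Nc1ccc(-c2nc3ccccc3o2)cc1)c1ccc(Cl)c(Cl)c1`. It differs from compound 1 by chloro in place of trifluoromethyl on an aromatic carbon. Among the measured compounds shown here, no measured step tests this change: the one step available, from compound 1 to compound 2, alters the halogen that stays in place here, not the trifluoromethyl, and it was modest. Compound 3 offers no guidance on a single group. With nothing pointing strongly either way, compound 4 is expected to sit close to compound 1 in this assay, the step from compound 1 to compound 4 estimated at a 1.3-fold higher number from compound 1 to compound 4 (0.10 log units; within the scatter). The expected value for compound 4 is therefore 15000 nM, within a range of 6000 nM to 40000 nM.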

Compound 4, half-maximal inhibitory concentration: 25000 nM
Estimate against measurement, compound 4: 1.7-fold (0.22 log units) below, and the stated range covers the measured number.
By their numbers in this assay, from the lowest: compound 1; then compounds 4 and 2 (each within the scatter of the next); then compound 3.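

In this assay, chloro does not fully stand in for trifluoromethyl at this position: a 2.1-fold higher number from compound 1 to compound 4 (0.32 log units; beyond the scatter), a modest change but one beyond the scatter. Among these compounds, this is the first measured change at this position, since the earlier step, a 2.3-fold higher number from compound 1 to compound 2 (0.37 log units; beyond the scatter), replaced the chloro group and left the trifluoromethyl in place. Both single changes made to compound 1 therefore give a modestly higher number, although nothing shown bears on why this change does so.

The compounds shown leave open what a nitrile, a methyl or a methoxy group would give at this position, and what hydrogen alone would give there. As far as these compounds go, the step also rests on a single pair of compounds with a chloro group as the other substituent, so it remains open whether the same change would give a similar step with fluoro in that place, as in compound 2, or with an amine on that carbon.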